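This account rests on a few compounds, and the source may have more. Where it says the series, first, only, none or still open, it means among the compounds named here.

In an ADME assay on MT4 cells (Homo sapiens) for cytotoxicity, read by MTT assay (on this read-out higher numbers stand for lower toxicity in this test and lower numbers for higher toxicity in this test), compound 1 (`Cc1cccc(C(=O)N(C(=S)OCCN2C(=O)c3ccccc3C2=O)c2ccc(Cl)cc2)c1`) gives 58000 nM, compound 2 (`O=C1c2ccccc2C(=O)N1CCOC(=S)N(C(=O)c1cc(Cl)cc(Cl)c1)c1ccc(Cl)cc1`) gives 32000 nM and compound 3 (`Cc1cc(C(=O)N(C(=S)OCCN2C(=O)c3ccccc3C2=O)c2ccc(Cl)cc2)ccc1Br`) gives 18000 nM. Compound 3 therefore stands with compound 2 at the low end of these numbers: the measured steps are a 1.8-fold lower number from compound 2 to compound 3 (0.25 log units; within the scatter) and a 3.2-fold lower number from compound 1 to compound 3 (0.51 log units; beyond the scatter). The remaining step, a 1.8-fold lower number from compound 1 to compound 2 (0.26 log units; within the scatter), also bears on the question. Compound 4 (`O=C1c2ccccc2C(=O)N1CCOC(=S)N(C(=O)c1cc2ccccc2s1)c1ccc(Cl)cc1`) carries 1-benzothiophen-2-yl in place of 4-bromo-3-methylphenyl on a carbonyl carbon. All three measured steps alter the group at this same place, and the largest is modest, so no step beyond the scatter is expected in this assay. The expected step is a 1.4-fold higher number from compound 3 to compound 4 (0.14 log units; within the scatter). For compound 4 the estimated value is 25000 nM, with an expected range from 10000 nM to 60000 nM.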

Compound 4, half-maximal cytotoxic concentration: 56000 nM
The estimate for compound 4 lay 2.2-fold (0.35 log units) below the measured number; the range from low to high includes it.
By their numbers in this assay, from the lowest: compounds 3, 2, 4 and 1 (each within the scatter of the next, the first and the last beyond it).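

In this assay, 1-benzothiophen-2-yl in place of 4-bromo-3-methylphenyl gives a 3.1-fold higher number from compound 3 to compound 4 (0.49 log units; beyond the scatter), so this position also accepts a group with a five-membered aromatic ring, and the change here goes beyond the scatter. Against the other two groups the picture differs: a 1.8-fold higher number from compound 2 to compound 4 (0.24 log units; within the scatter) and a 1.0-fold lower number from compound 1 to compound 4 (0.02 log units; within the scatter) both lie within the scatter, so compound 3 alone stands apart from compound 4. Nothing available explains this difference. On these data alone, it remains open how an amine or a carboxylic acid on this carbonyl carbon would read in this test.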